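Urea aryl swap on a pyrazole core: thermal shift

The compounds below may be only part of what the source reports. "The series", "measured", "known", "first", "only" and "open" are said of these compounds alone.

Compound 1, `Cc1ccccc1NC(=O)Nc1cc(C(C)(C)C)nn1-c1ccccc1`, in an assay on isolated protein for inhibition of STE20-like serine/threonine-protein kinase (Homo sapiens), read by thermal shift assay, tested at 10 uM; a higher number here means that the compound stabilises the target more against heat, a lower number that the compound stabilises the target less: 7.1 degrees C
Compound 2, `CC(C)(C)c1cc(NC(=O)Nc2ccccc2)n(-c2ccccc2)n1`, in this assay: 7.7 degrees C

For the measured compounds named here, compound 1 stands lowest of the two measured numbers, but its nearest neighbour is compound 2, and the only measured step, a number 0.60 degrees C higher from compound 1 to compound 2 (within the scatter), falls within the scatter, so the two cannot be ordered. That step removes a methyl from the aryl group on the urea nitrogen. Compound 3, `COc1cccc(NC(=O)Nc2cc(C(C)(C)C)nn2-c2ccccc2)c1`, has not been measured; it differs from compound 1 by 3-methoxyphenyl in place of 2-methylphenyl on an amide-type nitrogen. Going by the values given here, the one measured step bears on it only loosely, since it shows that losing the methyl on that aryl group changes nothing beyond the scatter, while the methoxy group entering here has no measured counterpart. The expected step, a number 0.30 degrees C higher from compound 1 to compound 3 (within the scatter), is therefore small, with no direction claimed beyond the scatter. Compound 3 is estimated at 7.4 degrees C, within a range from 5.4 degrees C to 9.4 degrees C.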

Compound 3, shift of the target's melting temperature: 3.6 degrees C
Compound 3: the middle estimate sits 3.8 degrees C above what was measured, outside the stated range (below it).
By their numbers in this assay, from the lowest: compound 3; then compounds 1 and 2 (each within the scatter of the next).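

The aryl group on the amide-type nitrogen matters more in this assay than the step between compound 1 and compound 2 suggested: 3-methoxyphenyl in place of 2-methylphenyl gives a number 3.5 degrees C lower from compound 1 to compound 3 (beyond the scatter). Methoxy in place of hydrogen on an aromatic carbon gives a number 4.1 degrees C lower from compound 2 to compound 3 (beyond the scatter), so this substituent changes the thermal shift clearly, whereas the methyl group of compound 1 did not change it beyond the scatter. Nothing available here accounts for the drop.

From the compounds shown here alone, it remains open whether the drop goes with the methoxy group itself or with where it sits on the aryl group; a 2-methoxyphenyl or a 3-methylphenyl on that nitrogen would separate the two. A 3-hydroxyphenyl or a 3-aminophenyl there would show how far other groups at that place follow compound 3.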